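The source may hold more compounds than are shown below. What is called first, only, known or untested is meant among the compounds shown, and "the series" means these compounds.

Working notes on the series. The shared core is a piperazine amide carrying a benzyloxyacetyl group, with an aryl ring on the other ring nitrogen. Among the compounds with values here, compound 1 `O=C(COCc1ccccc1)N1CCN(c2cccc(Cl)c2)CC1` gives 6700 nM in a functional assay on HEK293 cells for positive allosteric modulation of metabotropic glutamate receptor 5 (Homo sapiens), read by FLIPR and calcium flux (on this read-out lower numbers stand for an effect already at smaller amounts and higher numbers for an effect only at larger amounts of compound), and stands highest of the two numbers measured so far. Within the data shown here, compound 2 `O=C(COCc1ccccc1)N1CCN(c2ccc(F)cc2)CC1` gives 1100 nM in this assay; the only measured step is a 6.1-fold lower number from compound 1 to compound 2 (0.78 log units; beyond the scatter), a change of aryl group on the ring nitrogen.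

Compound 3 `O=C(COCc1ccccc1)N1CCN(c2ccc(Cl)cc2Cl)CC1` differs from compound 1 by 2,4-dichlorophenyl in place of 3-chlorophenyl on an amine nitrogen in a ring. Among the measured compounds shown here, no measured step covers this change: the step from compound 1 to compound 2 replaces the aryl group altogether rather than adding a second chlorine, so it sets only a loose precedent that a different halogen pattern on that ring can move this assay by a modest amount. A modest step in either direction, or none beyond the scatter, is therefore possible. Compound 3 is estimated at 4000 nM in this assay, with a range from 1000 nM to 15000 nM, corresponding to an expected step of a 1.7-fold lower number from compound 1 to compound 3 (0.22 log units; within the scatter).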

Compound 3, half-maximal effective concentration: 1000 nM
The estimate for compound 3 lay 4.0-fold (0.60 log units) above the measured number; the measured number falls inside the stated range.
By their numbers in this assay, from the lowest: compounds 3 and 2 (each within the scatter of the next); then compound 1.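

The step of a 6.7-fold lower number from compound 1 to compound 3 (0.83 log units; beyond the scatter) in this assay shows that the number at this position can also fall with chlorine kept on the aryl ring, so the earlier drop did not depend on a change to fluorine. The step of a 1.1-fold lower number from compound 2 to compound 3 (0.04 log units; within the scatter) leaves 4-fluorophenyl and 2,4-dichlorophenyl on a level within the scatter, and among the three aryl groups on the ring nitrogen, only 3-chlorophenyl stands apart. Nothing available here explains these differences.

The compounds shown leave open which chlorine of the 2,4-dichlorophenyl group accounts for the step, and how a nitrile or a methoxy group on that aryl ring would read. The benzyloxyacetyl group stays constant throughout, so they say nothing about a longer chain or an amine in its place.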